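The source may hold more compounds than are shown below. What is called first, only, known or untested is meant among the compounds shown, and "the series" means these compounds.

Measured compounds in a functional assay on ECa-109 cells (Homo sapiens) for antiproliferative activity, read by MTT assay, with a stated time of 72 h; on this read-out higher numbers stand for weaker inhibition and lower numbers for stronger inhibition:
compound 1 `CCCSc1nc(N/N=C/c2ccccc2Cl)c2nnn(Cc3ccccc3)c2n1`; compound 1 gives 6180 nM.
compound 2 `CCCSc1nc(N/N=C/c2ccc(Cl)cc2)c2nnn(Cc3ccccc3)c2n1`; compound 2 gives > 64000 nM, which is a limit of the assay.
compound 3 `CCCSc1nc(N/N=C/c2cccs2)c2nnn(Cc3ccccc3)c2n1`; compound 3 gives > 64000 nM, which is also a limit.

Compound 3 therefore has no number of its own in this assay; it sits at the limit that two of the three values share (the limit of > 64000 nM in this assay, at which 2 of the 3 values shown sit). Compound 4 `CCCSc1nc(N/N=C/c2c(O)ccc3ccccc23)c2nnn(Cc3ccccc3)c2n1` differs from compound 3 by 2-hydroxynaphthalen-1-yl in place of thiophen-2-yl on a carbon with a double bond to nitrogen. Two measured steps end at compound 3: an at least 10-fold higher number from compound 1 to compound 3 (1.01 log units; beyond the scatter), and a step that the two limits leave unreadable from compound 2 to compound 3. Within the data shown here, neither involves a naphthyl group, so the change itself is untested; what is known is only that the shared core, with a 2-chlorophenyl group on the carbon double-bonded to nitrogen, is the one case with a readable number, while the 4-chlorophenyl and thiophen-2-yl cases end at the limit. With compound 3 at the limit, the step from compound 3 to compound 4 is expected to run toward a lower number, an at least 3.2-fold lower number from compound 3 to compound 4 (0.50 log units; beyond the scatter), though a further limit is about as likely as a number. Compound 4 is accordingly estimated at 20000 nM, with a range from 3000 nM to 64000 nM.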

Compound 4, half-maximal inhibitory concentration: 9290 nM
For compound 4 the middle estimate is 2.2-fold (0.33 log units) above the measured one, and the stated range covers the measured number.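

In this assay, 2-hydroxynaphthalen-1-yl on a carbon with a double bond to nitrogen gives a readable number where thiophen-2-yl and 4-chlorophenyl do not, with an at least 6.8-fold lower number from compound 3 to compound 4 (0.83 log units; beyond the scatter) and an at least 6.8-fold lower number from compound 2 to compound 4 (0.83 log units; beyond the scatter). Both steps are bounds only, as the values of compound 2 and compound 3 are limits of the assay: the limit of > 64000 nM in this assay, at which 2 of the 4 values shown sit. Against 2-chlorophenyl the change gives a 1.5-fold higher number from compound 1 to compound 4 (0.18 log units; within the scatter), so the two groups cannot be told apart here, and a readable number at this place is no longer confined to a single group.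

The compounds shown do not separate the hydroxyl from the second aromatic ring of 2-hydroxynaphthalen-1-yl. As far as these compounds go, whether a plain naphthyl group, a hydroxyphenyl group or an amine-bearing phenyl group would keep a readable number stays open.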